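This account rests on a few compounds, and the source may have more. Where it says the series, first, only, none or still open, it means among the compounds named here.

Measured compounds in a functional assay on HeLa cells (Homo sapiens) for antiproliferative activity, read by CCK-8 assay, with a stated time of 72 h; a lower number here means a stronger inhibitor of growth, a higher number a weaker inhibitor of growth:
compound 1 `CCC1C(=O)N(C)c2cnc(-n3ccc4cc(C(N)=O)ccc43)nc2N1c1ccn(C)n1`: 27400 nM
compound 2 `CC[C@@H]1C(=O)N(C)c2cnc(Nc3ccc(S(=O)(=O)NC4CCCC4)cc3)nc2N1C1CCCC1`: 609 nM
compound 3 `CCC1C(=O)N(C)c2cnc(Nc3ccc(S(=O)(=O)NCC(C)C)cc3)nc2N1c1ccn(C)n1`: 5310 nM

Compound 3 stands second highest of the three numbers in this assay. Compound 1 gives a higher number, beyond the scatter; compound 2 gives a lower number, also beyond the scatter. Among the measured compounds shown here, no two measured compounds differ in only one place, so none of these gaps is assigned to a single change.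

Compound 4 `CCC1C(=O)N(C)c2cnc(Nc3ccc(S(=O)(=O)NCCO)cc3)nc2N1c1ccn(C)n1` is not yet measured. It differs from compound 3 as follows: hydroxymethyl in place of isopropyl on a saturated chain carbon bound to a sulfonamide nitrogen. For the measured compounds named here, no measured pair isolates this change. The step expected here is a 1.3-fold higher number from compound 3 to compound 4 (0.12 log units; within the scatter), within the usual scatter, if anything toward a weaker inhibitor. Compound 4 is estimated at 7000 nM, with a range of 2500 nM to 20000 nM.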

Compound 4, concentration for 50% growth inhibition: "not active" (no number reported)
No number was reported for compound 4, so the estimate cannot be set against anything.
By their numbers in this assay, from the lowest: compound 2; then compound 3; then compound 1.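

In this assay, among the compounds shown here, compound 4 is reported as "not active" without a number, so no step from compound 3 can be read. The compounds shown leave open what isobutyl to 2-hydroxyethyl alone does to growth inhibition. No measurement offers an explanation for this result.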